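A few compounds are considered here, and "the series" means these few. Any claim that something is new, unique, unknown or untested is made for them only; others in the source may bear on it.

Measured compounds:
- compound 1, `CN1CCN(CCn2c(=O)oc3cccnc32)CC1`: in a functional assay on the whole organism with Mus musculus as the target (a lower number here means that less compound is needed, a higher number that more compound is needed for the effect), compound 1 gives > 25 mg/kg, which is a limit of the assay and not a number.
- compound 2, `COc1ccccc1N1CCN(Cn2c(=O)oc3cccnc32)CC1`: in this assay compound 2 gives > 25 mg/kg, likewise a limit.
- compound 3, `CCN(CC)CCn1c(=O)oc2cccnc21`: in this assay compound 3 gives > 25 mg/kg, again a limit.

Compound 3 therefore stands where the whole set stands: the limit of > 25 mg/kg in this assay, at which 3 of the 3 values shown sit. No measured step between any two of these compounds exists, so nothing in the set shows how a change at the amine end of the chain moves the read-out, and none of the three compounds can be placed above or below another.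

Compound 4, `O=c1oc2cccnc2n1CCN1CCCCC1`, is the untested member. It differs from compound 3 in one place: piperidin-1-yl in place of diethylamino on a saturated chain carbon, two bonds along the chain from an aromatic nitrogen. Piperidin-1-yl thus replaces diethylamino on the same saturated chain carbon, two bonds along the chain from the aromatic nitrogen. The step from compound 3 to compound 4 in this assay is expected to be a step that the limit leaves unreadable from compound 3 to compound 4, that is, nothing beyond the usual scatter, since compound 3 itself shows only (the limit of > 25 mg/kg in this assay, at which 3 of the 3 values shown sit).

For compound 4 the expected dose for half-maximal effect in this assay is 40 mg/kg, with a range from 15 mg/kg to 150 mg/kg, and the most likely outcome is that the assay once more reports only a limit.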

Compound 4, dose for half-maximal effect: > 25 mg/kg
Compound 4 ended at the assay's limit; the forecaster's own chance of this, stated with the estimate: 75%; the middle value is on the limit's open side.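

In this assay compound 4 gives > 25 mg/kg, a limit of the assay and not a number. The step between compound 3 and compound 4 cannot be read, because both compounds end at the same limit: the limit of > 25 mg/kg in this assay, at which 4 of the 4 values shown sit.

The compounds shown leave open whether any of these amine ends gives a readable dose in this assay, and how they would rank.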